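A Group Swap After Two Level Compounds

The source may hold more compounds than are shown below. What is called first, only, known or untested is meant among the compounds shown, and "the series" means these compounds.

In an ADME assay on HepG2 2.2.15 cells (Homo sapiens) for cytotoxicity, read by CCK-8 assay, with a stated time of 8 days (a lower number here means that less compound is tolerated, a higher number that more compound is tolerated), compound 1 (`COc1ccc(-c2cc(NC(=O)c3ccc(OC)cc3O)c[nH]c2=O)cc1`) gives 49900 nM and compound 2 (`COc1ccc(C(=O)Nc2c[nH]c(=O)c(-c3ccc(OC)c(F)c3)c2)c(O)c1`) gives 50500 nM so the two stand level. Compound 3 (`COc1ccc(C(=O)Nc2c[nH]c(=O)c(-c3cc(C)ccc3C)c2)c(O)c1`) carries 2,5-dimethylphenyl in place of 3-fluoro-4-methoxyphenyl on an aromatic carbon. For the measured compounds named here, the only measured step, fluoro in place of hydrogen on an aromatic carbon, was a 1.0-fold higher number from compound 1 to compound 2 (0.01 log units; within the scatter) and is a weak guide to replacing a whole group. No clear shift is therefore expected in this assay although the uncertainty stays wide. The estimate amounts to a 1.1-fold lower number from compound 2 to compound 3 (0.05 log units; within the scatter) and remains an expectation. For compound 3 the estimated value is 45000 nM with an expected range from 18000 nM to 100000 nM until it is measured.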

Compound 3, half-maximal cytotoxic concentration: 50400 nM
Compound 3: middle estimate off by 1.1-fold (0.05 log units), on the low side; the measured number falls inside the stated range.
By their numbers in this assay, from the lowest: compounds 1, 3 and 2 (each within the scatter of the next).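

In this assay, exchanging the whole group at this position, rather than a single hydrogen, still leaves the compounds level: a 1.0-fold lower number from compound 2 to compound 3 (0.00 log units; within the scatter), and a 1.0-fold higher number from compound 1 to compound 3 (0.00 log units; within the scatter). A ring carrying two methyl groups, with no oxygen or fluorine, thus stands level with the methoxy-bearing rings of the two earlier compounds. Nothing available explains this level result.

From the compounds shown here alone, all three compounds carry a carbon-only aromatic ring here, so it remains open whether a group bearing an amine or a carboxylic acid would also stay level. Changes elsewhere on the shared core also remain open.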